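The source may hold more compounds than are shown below. What is called first, only, known or untested is meant among the compounds shown, and "the series" means these compounds.

Compound 1 `N=C(NCCCc1c[nH]cn1)NCCC(c1ccccc1)c1ccccn1` and compound 2 `N=C(NCCCc1c[nH]cn1)NCCC(c1ccc(Br)cc1)c1ccccn1` share a core and differ only by bromo in place of hydrogen on an aromatic carbon. In a functional assay on muscle tissue for agonist activity at histamine H2 receptor (Cavia porcellus) (on this read-out lower numbers stand for lower potency and higher numbers for higher potency (the scale is a negative logarithm)), compound 1 gives 7.37, and compound 2 gives 6.97. For the measured compounds named here, the step of a number 0.40 log units lower from compound 1 to compound 2 (beyond the scatter) shows that this halogen on the aromatic ring costs a modest amount of potency, and it leaves compound 1 as the higher of the two numbers measured so far.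

Compound 3 `N=C(NCCCc1c[nH]cn1)NCCC(c1ccccc1)c1ccc(Cl)c(Cl)c1` has not been measured. It differs from compound 1 by 3,4-dichlorophenyl in place of pyridin-2-yl on a saturated chain carbon bound to an aromatic carbon and a saturated chain carbon. Going by the values given here, no measured step covers an exchange of one ring for another, so the only guide is the halogen step from compound 1 to compound 2, which was modest and downward; two chlorines arrive here, and the pyridin-2-yl ring departs, so the expected step of a number 0.77 log units lower from compound 1 to compound 3 (beyond the scatter) is downward and somewhat larger. In this assay compound 3 is therefore expected to give about 6.6, within a range from 6 to 7.2.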

Compound 3, negative logarithm of the half-maximal effective concentration: 6.03
The estimate for compound 3 lay 0.57 log units above the measured number; low and high end bracket the measured number.
By their numbers in this assay, from the lowest: compound 3; then compound 2; then compound 1.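

The ring on this saturated chain carbon matters a great deal in this assay: a number 1.34 log units lower from compound 1 to compound 3 (beyond the scatter), a large step, whereas the bromo exchange on the aromatic ring that left pyridin-2-yl in place was only modest, a number 0.40 log units lower from compound 1 to compound 2 (beyond the scatter). This single exchange does two things at once, removing the ring nitrogen, which is counted as a hydrogen-bond acceptor, and bringing in two chlorine atoms, so the step cannot be divided between them. No measurement here explains why potency falls.

As far as these compounds go, it remains open how much of the loss would appear with a plain phenyl at this carbon, and how much with a phenyl ring carrying a single chlorine. A thiophene ring at the same carbon would show whether other rings can take the place of pyridin-2-yl.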